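Phenyl in place of methyl on a ring nitrogen

The compounds below may be only part of what the source reports. "The series", "measured", "known", "first", "only" and "open" are said of these compounds alone.

In an ADME assay on Vero cells (Chlorocebus sabaeus) for cytotoxicity, read by neutral red uptake, with a stated time of 48 h (a higher number here means a weaker inhibitor, a lower number a stronger inhibitor), compound 1 (`CN(C)c1nc(Cl)nc2c1ncn2CCNc1ccnc2cc(Cl)ccc12`) gives > 11800 nM as a limit, not a number. Compound 2 (`Clc1ccc2c(NCCn3cnc4c(N5CCCCCC5)nc(Cl)nc43)ccnc2c1`) gives > 10400 nM as a limit too. Compound 3 (`CN1CCN(c2nc(Cl)nc3c2ncn3CCNc2ccnc3cc(Cl)ccc23)CC1`) likewise gives > 10400 nM as a limit, so none of the three compounds has yet given a true number.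

Compound 4 (`Clc1ccc2c(NCCn3cnc4c(N5CCN(c6ccccc6)CC5)nc(Cl)nc43)ccnc2c1`) carries phenyl in place of methyl on an amine nitrogen in a ring, turning 4-methylpiperazin-1-yl into 4-phenylpiperazin-1-yl (phenyl in place of methyl on an amine nitrogen in a ring). Within the data shown here, two measured steps bear on this change: a step that the two limits leave unreadable from compound 1 to compound 3 and then a step that the two limits leave unreadable from compound 2 to compound 3 and neither offers a size to carry over. With no measured size to build on, the safest expectation is no shift beyond the usual scatter in either direction. The expected change is an at least 1.0-fold lower number from compound 3 to compound 4 (0.03 log units; that floor lies within the scatter) and it is only a cautious estimate. For compound 4 the estimated value is 9500 nM with an expected range from 4000 nM to 20000 nM and another limit is the likeliest outcome.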

Compound 4, half-maximal inhibitory concentration: 4040 nM
Estimate against measurement, compound 4: 2.4-fold (0.37 log units) above; the measured number falls inside the stated range.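

Among these compounds, putting phenyl in place of methyl on the amine nitrogen of the ring gives an at least 2.5-fold lower number from compound 3 to compound 4 (0.41 log units; beyond the scatter) in this assay and yields the first true number in this set. The 4-phenylpiperazin-1-yl group also gives an at least 2.5-fold lower number from compound 2 to compound 4 (0.41 log units; beyond the scatter) when it replaces azepan-1-yl and an at least 2.9-fold lower number from compound 1 to compound 4 (0.46 log units; beyond the scatter) when it replaces dimethylamino, so the group at this position can move the read-out. The steps among compound 1, compound 2 and compound 3 cannot be read, and the new steps are only floors because their starting values are limits: the limit of > 10400 nM in this assay, at which 2 of the 4 values shown sit.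

From the compounds shown here alone, it remains open whether the drop comes from the aromatic ring itself or simply from the added carbons. A benzyl or an acetyl on the same ring nitrogen would help separate the two, and a chlorine or methoxy on the phenyl ring would test how far the effect can be tuned.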